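The source may hold more compounds than are shown below. What is called first, only, known or untested is meant among the compounds shown, and "the series" means these compounds.

Measured so far:
Compound 1 `CN(C)c1ccc(C2CC(c3ccc(-n4ccnc4)cc3)=NN2C(=O)c2ccc(F)cc2)cc1` — -3.5%
Compound 2 `Cc1ccc(S(=O)(=O)N2N=C(c3ccc(-n4ccnc4)cc3)CC2c2ccc(N(C)C)cc2)cc1` — 50.5%

In a functional assay on NCI-H1975 cells (Homo sapiens) for inhibition, read by sulforhodamine B assay, tested at 10 uM (on this read-out lower numbers stand for less inhibition and higher numbers for more inhibition at the one concentration tested (going by the name of the read-out)), compound 2 stands highest of the two numbers, with compound 1 the nearest a number 54 percentage points higher from compound 1 to compound 2 (beyond the scatter). Compound 3 `CN(C)c1ccc(C2CC(c3ccc(-n4ccnc4)cc3)=NN2S(=O)(=O)c2ccc(C#N)cc2)cc1` keeps the sulfonyl of compound 2 and differs only in cyano in place of methyl on an aromatic carbon. For the measured compounds named here, the one measured step concerns the exchange of the carbonyl for the sulfonyl, not the group on the sulfonyl-bearing ring, so it gives no direct guide to this change. With no comparison of that kind available, the step is expected to be small, a number 2.5 percentage points lower from compound 2 to compound 3 (within the scatter), within the scatter. Compound 3 is therefore estimated at 48%, between 25% and 70%.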

Compound 3, a percentage reported as inhibition, at one concentration (the size of the read-out at that concentration, not a potency): 0.7%
Compound 3: the middle estimate sits 47.3 percentage points above what was measured; measured number below the stated range.
By their numbers in this assay, from the lowest: compounds 1 and 3 (each within the scatter of the next); then compound 2.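

In this assay the group on the sulfonyl-bearing ring proves decisive: cyano in place of methyl gives a number 49.8 percentage points lower from compound 2 to compound 3 (beyond the scatter) and removes what compound 2 had gained, so the sulfonyl alone does not account for that inhibition. With a number 4.2 percentage points higher from compound 1 to compound 3 (within the scatter) as the remaining comparison, the sulfonyl-for-carbonyl exchange pays off with the 4-methylphenyl group but not with the 4-cyanophenyl group. Nothing available explains this dependence on the ring substituent.

From the compounds shown here alone, whether the methyl itself is needed remains open. An ethyl, a methoxy or an amine at the same place on the ring would help to show how narrow this requirement is.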